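The source may hold more compounds than are shown below. What is called first, only, known or untested is meant among the compounds shown, and "the series" means these compounds.

Compound 1 `Oc1ccc(-c2cc(-c3cccc(Cl)c3)nc(-c3ccccn3)c2)cc1` was tested in a functional assay on DU-145 cells (Homo sapiens) for cytotoxicity, read by CCK-8 assay and cell counting, with a stated time of 2 days; a lower number here means a stronger inhibitor, a higher number a weaker inhibitor. In this assay compound 1 gives 35200 nM. That is the higher of the two numbers recorded. The nearest is compound 2 `Oc1ccc(-c2cc(-c3ccccc3)nc(-c3ccccc3Cl)c2)cc1`, which in this assay gives 2800 nM, a lower number by a gap beyond the usual scatter. Compound 3 `Oc1cccc(-c2cc(-c3cccc(Cl)c3)nc(-c3ccccn3)c2)c1` was also prepared, but in this assay compound 3 is recorded as "not determined" (no result reported), so no number was reported for it. Compound 4 `Oc1ccc(-c2cc(-c3cccnc3)nc(-c3cccc(Cl)c3)c2)cc1` differs from compound 1 in one place: pyridin-3-yl in place of pyridin-2-yl on an aromatic carbon. For the measured compounds named here, no measured pair shows such a change, so no size of step can be read from the other compounds. For compound 4 the step of a 1.2-fold lower number from compound 1 to compound 4 (0.07 log units; within the scatter) is therefore expected to be small, not beyond the scatter in either direction. Compound 4 is expected to give about 30000 nM in this assay, within a range of 8000 nM to 100000 nM.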

Compound 4, half-maximal inhibitory concentration: 22900 nM
Compound 4: the middle estimate sits 1.3-fold (0.12 log units) above what was measured, within the range that was stated.
By their numbers in this assay, from the lowest: compound 2; then compounds 4 and 1 (each within the scatter of the next).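

Pyridin-3-yl in place of pyridin-2-yl on this aromatic carbon, next to the ring nitrogen, now has a measured step: in this assay it is a 1.5-fold lower number from compound 1 to compound 4 (0.19 log units; within the scatter), so this exchange does not separate the two compounds. No measurement shown gives a reason for this result. On these data alone, it remains open whether pyridin-4-yl, an amine or a carboxylic acid on this same carbon would move the number beyond the scatter, and whether the exchange would give a similar step on another version of the core.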